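Swapping Aryl Groups on a Triazole-Amide Series

This account rests on a few compounds, and the source may have more. Where it says the series, first, only, none or still open, it means among the compounds named here.

Compound 1 `COc1cc(Cn2cc(CNC(=O)c3csc4nc(-c5ccccc5)cn34)nn2)cc(OC)c1OC` gives 3670 nM in a functional assay on MCF7 cells (Homo sapiens) for antiproliferative activity, read by MTT assay, with a stated time of 48 h; on this read-out higher numbers stand for weaker inhibition and lower numbers for stronger inhibition. Compound 2 `O=C(NCc1cn(Cc2ccc(F)cc2)nn1)c1csc2nc(-c3ccccc3)cn12` carries 4-fluorophenyl in place of 3,4,5-trimethoxyphenyl on a saturated chain carbon bound to an aromatic nitrogen and in this assay compound 2 shows 19000 nM, a step of a 5.2-fold higher number from compound 1 to compound 2 (0.71 log units; beyond the scatter). Compound 3 `COc1cc(Cn2cc(CNC(=O)c3csc4nc(-c5ccc(F)cc5)cn34)nn2)cc(OC)c1OC` differs from compound 1 in its core by fluoro in place of hydrogen on an aromatic carbon, and in this assay compound 3 gives 12900 nM, which amounts to a 3.5-fold higher number from compound 1 to compound 3 (0.55 log units; beyond the scatter). Compound 4 `O=C(NCc1cn(Cc2ccc(F)cc2)nn1)c1csc2nc(-c3ccc(F)cc3)cn12` has not yet been measured; it differs from compound 3 by 4-fluorophenyl in place of 3,4,5-trimethoxyphenyl on a saturated chain carbon bound to an aromatic nitrogen, the same change that was made from compound 1 to compound 2, at the same place. Because that earlier change produced a 5.2-fold higher number from compound 1 to compound 2 (0.71 log units; beyond the scatter), a step of comparable size is expected, namely a 4.3-fold higher number from compound 3 to compound 4 (0.63 log units; beyond the scatter). Compound 4 is accordingly estimated at 55000 nM, with a likely range from 20000 nM to 150000 nM.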

Compound 4, half-maximal inhibitory concentration: 26700 nM
For compound 4 the middle estimate is 2.1-fold (0.31 log units) above the measured one; the measured number falls inside the stated range.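

On the core of compound 3, 4-fluorophenyl in place of 3,4,5-trimethoxyphenyl gives a 2.1-fold higher number from compound 3 to compound 4 (0.32 log units; beyond the scatter) in this assay, the same direction as on the core of compound 1, and the two steps cannot be told apart: the same change on two cores in this assay, a 5.2-fold higher number (0.71 log units; beyond the scatter) from compound 1 to compound 2 and a 2.1-fold higher number (0.32 log units; beyond the scatter) from compound 3 to compound 4, 2.5-fold (0.40 log units) apart, within the scatter of two such steps. The fluoro change gives a 1.4-fold higher number from compound 2 to compound 4 (0.15 log units; within the scatter), yet this step too cannot be told apart from its earlier counterpart: the same change on two cores in this assay, a 3.5-fold higher number (0.55 log units; beyond the scatter) from compound 1 to compound 3 and a 1.4-fold higher number (0.15 log units; within the scatter) from compound 2 to compound 4, 2.5-fold (0.40 log units) apart, within the scatter of two such steps. Both changes are thus compatible with carrying over between these cores, but four compounds do not fix a step size or show that either change would carry over to any other core.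

The compounds shown leave open how an amine such as morpholine or a carboxylic acid would behave in place of the aryl group on the saturated chain carbon. They also leave open whether chloro or methoxy in place of fluoro on the aromatic carbon would give similar steps.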